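The source may report more compounds than this note shows. Statements on the series, on what has been measured and on what is new or still open speak of the compounds shown alone.

Among the measured compounds shown here, compound 2, `CC(=O)OCCCc1ccc(C(=O)CCCN2CCC(C(O)(c3ccccc3)c3ccccc3)CC2)cc1`, holds the lower of the two numbers measured so far in an in vitro assay on Sf9 cells for inhibition of cytochrome P450 2J2 (Homo sapiens); a higher number here means a weaker inhibitor, a lower number a stronger inhibitor: compound 2 gives 2500 nM. For the measured compounds named here, its only neighbour is compound 1, `COc1ccc(C(=O)CCCN2CCC(C(O)(c3ccccc3)c3ccccc3)CC2)cc1`, which in this assay gives 7600 nM; the gap between them is a 3.0-fold lower number from compound 1 to compound 2 (0.48 log units; beyond the scatter), and it lies beyond the usual scatter of repeated measurements.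

Compound 3, `Cc1ccc(C(=O)CCCN2CCC(C(O)(c3ccccc3)c3ccccc3)CC2)cc1`, has not yet been measured. It differs from compound 2 by hydrogen in place of 2-acetoxyethyl on a saturated chain carbon bound to an aromatic carbon; read one bond further out, the 3-acetoxypropyl chain of compound 2 becomes a methyl group in compound 3. Going by the values given here, only one measured step bears on this change, a 3.0-fold lower number from compound 1 to compound 2 (0.48 log units; beyond the scatter), in which that same chain came in for methoxy. Compound 3 carries neither the chain nor the methoxy, so its number is expected to move back toward that of compound 1 rather than stay with compound 2. The expected step is a 2.4-fold higher number from compound 2 to compound 3 (0.38 log units; beyond the scatter), toward a higher number. Compound 3 is therefore estimated at 6000 nM, with a likely range from 2500 nM to 15000 nM.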

Compound 3, half-maximal inhibitory concentration: 700 nM
Compound 3: the middle estimate sits 8.6-fold (0.93 log units) above what was measured, outside the stated range (below it).
By their numbers in this assay, from the lowest: compound 3; then compound 2; then compound 1.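

In this assay, methyl in place of methoxy on an aromatic carbon gives an 11-fold lower number from compound 1 to compound 3 (1.04 log units; beyond the scatter), a large step, while shortening the 3-acetoxypropyl chain to methyl gives a 3.6-fold lower number from compound 2 to compound 3 (0.55 log units; beyond the scatter). The earlier comparison made the 3-acetoxypropyl chain look like a gain, but the new result shows that this holds only against methoxy: against methyl, the chain goes with a weaker inhibitor. At this place, then, the three groups order as methyl, 3-acetoxypropyl and methoxy, from the lowest number to the highest, and a small change of methoxy to methyl moves the number further than either step involving the long chain; nothing measured here explains this order.

The three compounds leave open how the number changes along the way from methyl to the long chain, since an ethyl or propyl group would show whether length alone raises it, and a 3-hydroxypropyl chain would test the acetoxy end separately. They also leave open whether plain hydrogen, chlorine or an amine at this place would match methyl or differ from it.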